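From compound 1 to compound 3: a sulfonyl swap

This account rests on a few compounds, and the source may have more. Where it says the series, first, only, none or still open, it means among the compounds named here.

- Compound 1 `CC(C)(CO)S(=O)(=O)c1cccc(NC(=O)c2cccnc2N2CCC3(CC2)CC3)c1`: 45900 nM
- Compound 2 `CC(C)(C)NS(=O)(=O)c1cccc(NC(=O)c2ncc(NC(C)(C)CO)nc2N2CCC3(CC2)CC3)c1`: 190 nM

In a functional assay on OVCAR-3 cells (Homo sapiens) for activation, with a stated time of 24 h (on this read-out higher numbers stand for an effect only at larger amounts of compound and lower numbers for an effect already at smaller amounts), compound 1 has the higher of the two numbers, and the gap down to compound 2 is beyond the usual scatter. Compound 3 `O=C(Nc1cccc(S(=O)(=O)C2COC2)c1)c1cccnc1N1CCC2(CC1)CC2` has not yet been measured. It differs from compound 1 by one change, oxetan-3-yl in place of 1-(hydroxymethyl)-1-methylethyl on a sulfonyl sulfur. Within the data shown here, no measured pair shows this change, so only a modest shift towards a lower number in this assay is expected. The expected step is a 2.3-fold lower number from compound 1 to compound 3 (0.36 log units; beyond the scatter). For compound 3 the estimated value is 20000 nM, with an expected range from 4000 nM to 60000 nM.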

Compound 3, half-maximal effective concentration: 14800 nM
For compound 3 the middle estimate is 1.4-fold (0.13 log units) above the measured one; measured number inside the range.
By their numbers in this assay, from the lowest: compound 2; then compound 3; then compound 1.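

In this assay oxetan-3-yl in place of 1-(hydroxymethyl)-1-methylethyl on a sulfonyl sulfur gives a 3.1-fold lower number from compound 1 to compound 3 (0.49 log units; beyond the scatter) as a modest step. This position therefore accepts a group with a four-membered ring and no hydrogen-bond donor, so the donor of the departing group is not needed for the effect seen here. Nothing available explains why the number falls. Still open, on these data alone, is how a cyclopropyl group or a longer chain ending in a carboxylic acid would fare on this sulfur. As far as these compounds go, whether the same swap gives a similar step on a different core also remains open.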